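A few compounds are considered here, and "the series" means these few. Any claim that something is new, unique, unknown or untested is made for them only; others in the source may bear on it.

Compound 2 `COc1ccccc1NC1=CC(=O)c2nc3n(c2C1=O)[C@H]1OC[C@@H](O)[C@H]1OC3` reaches only the limit in a functional assay on MCF7 cells (Homo sapiens) for inhibition, read by sulforhodamine B assay (on this read-out lower numbers stand for stronger inhibition and higher numbers for weaker inhibition), giving > 4000 nM. Compound 1 `O=C1C(Nc2ccccc2)=CC(=O)c2c1nc1n2[C@H]2OC[C@@H](O)[C@H]2OC1` likewise sits at the limit, with > 4000 nM. Compound 3 `CCOc1ccc(NC2=CC(=O)c3nc4n(c3C2=O)[C@H]2OC[C@@H](O)[C@H]2OC4)cc1` gives a number in this assay, 1430 nM. Among the measured compounds shown here, the one measured step, an at least 2.7-fold lower number from compound 2 to compound 3 (0.44 log units; beyond the scatter), concerns an exchange of one aryl group for another on the amine nitrogen, and its size is bounded because of the limit of > 4000 nM in this assay, at which 2 of the 3 values shown sit. Compound 4 `O=C1C=C(N2CCCC2)C(=O)c2c1nc1n2[C@H]2OC[C@@H](O)[C@H]2OC1` differs from compound 2 by pyrrolidin-1-yl in place of (2-methoxyphenyl)amino on a double-bonded ring carbon. For the measured compounds named here, no measured step covers loss of the arylamino group for a cyclic amine, so the direction is open; the series so far leaves both anilines with a bare aryl at the limit. Compound 4 is therefore expected near the limit as well, estimated at 4000 nM (range 1500 nM to 10000 nM), meaning an expected step of a number no higher from compound 2 to compound 4 (the limit leaves the size open).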

Compound 4, half-maximal inhibitory concentration: > 16000 nM
Compound 4: no number, only a limit; the forecaster's own chance of this, stated with the estimate: 55%; middle value at least 4.0-fold (0.60 log units) away from the limit.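

No new step can be read: compound 2 and compound 4 both stand only at limits in this assay, and the two limits cannot be compared. The compounds shown leave open how pyrrolidin-1-yl compares with (2-methoxyphenyl)amino on the shared core.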